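Amino in place of 3-fluorophenyl on a carbonyl carbon

The source may hold more compounds than are shown below. What is called first, only, known or untested is meant among the compounds shown, and "the series" means these compounds.

Compound 1 `Nc1nc(Nc2ccccc2)sc1C(=O)c1cccnc1`: 5900 nM
Compound 2 `Nc1nc(Nc2ccccc2)sc1C(=O)c1cccc(F)c1`: 3600 nM

In a functional assay on GC-1 cells (Mus musculus) for cytotoxicity, read by MTT assay, with a stated time of 72 h (a lower number here means a stronger inhibitor, a higher number a weaker inhibitor), compound 2 gives 3600 nM, which lies within the scatter of compound 1, so the two stand level. Going by the values given here, the only measured step is a 1.6-fold lower number from compound 1 to compound 2 (0.21 log units; within the scatter), with 3-fluorophenyl in place of pyridin-3-yl on a carbonyl carbon.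

Compound 3 `NC(=O)c1sc(Nc2ccccc2)nc1N` has not yet been measured. It carries amino in place of 3-fluorophenyl on a carbonyl carbon. The measured step bears on this change only loosely, since it exchanged one ring for another, whereas here a ring leaves and none enters. Among the compounds with values here, no measured compound shows what losing that ring does. Compound 1 at 5900 nM and compound 2 at 3600 nM both keep a ring there, so the direction of the change is a judgement, and a higher number is expected in this assay. The expected step is a 4.2-fold higher number from compound 2 to compound 3 (0.62 log units; beyond the scatter). For compound 3 the estimated value is 15000 nM, with an expected range of 5000 nM to 50000 nM.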

Compound 3, half-maximal inhibitory concentration: > 60000 nM
Compound 3: no number, only a limit; the forecaster's own chance of this, stated with the estimate: 25%; middle value at least 4.0-fold (0.60 log units) away from the limit.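

In this assay amino in place of 3-fluorophenyl gives an at least 16-fold higher number from compound 2 to compound 3 (1.22 log units; beyond the scatter) and amino in place of pyridin-3-yl gives an at least 10-fold higher number from compound 1 to compound 3 (1.00 log units; beyond the scatter) while the earlier exchange of one ring for the other stayed within the scatter. This position on the carbonyl carbon therefore accepted both rings shown at a level that cannot be told apart, and the first large change appears only when no ring remains there. Compound 3 carries a limit of the assay and not a number, so both new steps give only a minimum size and the full size of the loss stays unknown: the limit of > 60000 nM in this assay, at which 1 of the 3 values shown sits.

The compounds shown do not say whether a ring as such is needed or whether bulk alone would serve, since no open chain such as propyl, no dimethylamino group and no saturated ring such as cyclohexyl stands on this carbonyl carbon. They also leave open what plain phenyl would give there, and whether a methoxy group or a chlorine on the ring would move the number beyond the scatter.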